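The source may hold more compounds than are shown below. What is called first, only, known or untested is meant among the compounds shown, and "the series" means these compounds.

In a functional assay on A549 cells (Homo sapiens) for cytotoxicity, read by MTT assay, with a stated time of 72 h (a higher number here means a weaker inhibitor, a lower number a stronger inhibitor), compound 1 `O=C1c2c[n+]([O-])c3ccccc3c2C(=O)c2c1c1ccccc1n2Cc1cn(CC(O)CO)nn1` gives 880 nM, the second highest of the three numbers at hand. Compound 2 `CC1(C)O[C@@H](CO)[C@H](Cn2cc(Cn3c4c(c5ccccc53)C(=O)c3c[n+]([O-])c5ccccc5c3C4=O)nn2)O1` lies lower at 370 nM, and compound 3 `CC1(C)OC[C@@H](Cn2cc(Cn3c4c(c5ccccc53)C(=O)c3c[n+]([O-])c5ccccc5c3C4=O)nn2)O1` lies higher at 4700 nM.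

The next compound to consider is compound 4 `CN1CCN(CCCn2c3c(c4ccccc42)C(=O)c2c[n+]([O-])c4ccccc4c2C3=O)CC1`, which keeps the core of compound 1 but carries a different side chain: 2-(4-methylpiperazin-1-yl)ethyl in place of 1-(2,3-dihydroxypropyl)-1H-1,2,3-triazol-4-yl on a saturated chain carbon bound to an aromatic nitrogen. Put simply, 2-(4-methylpiperazin-1-yl)ethyl stands in place of 1-(2,3-dihydroxypropyl)-1H-1,2,3-triazol-4-yl on a saturated chain carbon bound to an aromatic nitrogen.

Among the compounds with values here, no measured step makes this swap. All three keep the triazole unit and change only the group attached to it. They are a 2.4-fold lower number from compound 1 to compound 2 (0.38 log units; beyond the scatter), a 5.3-fold higher number from compound 1 to compound 3 (0.73 log units; beyond the scatter) and a 13-fold higher number from compound 2 to compound 3 (1.10 log units; beyond the scatter). The first two are modest and the third is large, and together they show that edits to this side chain can move the number either way. They therefore suggest how wide the range should be, but give no direction for the larger swap. The expected change is thus none beyond the scatter, an estimated 1.1-fold lower number from compound 1 to compound 4 (0.04 log units; within the scatter). For compound 4, the expected value is 800 nM, with an estimated range of 150 nM to 4000 nM.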

Compound 4, half-maximal inhibitory concentration: 140 nM
Compound 4: middle estimate off by 5.7-fold (0.76 log units), on the high side; the whole stated range lies above it.
By their numbers in this assay, from the lowest: compound 4; then compound 2; then compound 1; then compound 3.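

In this assay, the step from the triazole side chain to the piperazine side chain gives a 6.3-fold lower number from compound 1 to compound 4 (0.80 log units; beyond the scatter), and compound 4 has the lowest number of the four compounds. The earlier compounds shown here changed only the group attached to the triazole unit, whereas this result shows that the position on a saturated chain carbon bound to an aromatic nitrogen can carry a side chain with no triazole and 0 hydrogen-bond donors without the number rising. Nothing available here explains this drop in the number.

The swap replaces the triazole, the diol and the linking chain together, so the compounds shown cannot separate what each part contributes to the lower number. A 3-(morpholin-4-yl)propyl or 3-(dimethylamino)propyl group in the same place would test whether the methylpiperazine ring itself matters, and a longer chain such as 4-(4-methylpiperazin-1-yl)butyl would test the role of chain length.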